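Swapping the benzylic ether for a benzylic amine

The compounds below may be only part of what the source reports. "The series", "measured", "known", "first", "only" and "open" are said of these compounds alone.

Compound 1 `CC[C@H](C)[C@H](N)CN(C(=O)[C@@H]1C[C@H]1c1ccccc1)c1ccc(-c2ccc(OC(C)C)cc2)cc1`: 72 nM
Compound 2 `CC[C@H](C)[C@H](N)CN(C(=O)[C@@H]1C[C@H]1c1ccccc1)c1ccc(-c2ccc(COC)cc2)cc1`: 35 nM

Of the compounds shown here, two have been measured in a functional assay for agonist activity at G protein-coupled receptor 88 (Homo sapiens), read by HTRF and cAMP accumulation; a lower number here means that less compound is needed, a higher number that more compound is needed for the effect. Compound 1 `CC[C@H](C)[C@H](N)CN(C(=O)[C@@H]1C[C@H]1c1ccccc1)c1ccc(-c2ccc(OC(C)C)cc2)cc1` gives 72 nM in this assay, and compound 2 `CC[C@H](C)[C@H](N)CN(C(=O)[C@@H]1C[C@H]1c1ccccc1)c1ccc(-c2ccc(COC)cc2)cc1` gives 35 nM. For the measured compounds named here, the single step between them, a 2.1-fold lower number from compound 1 to compound 2 (0.31 log units; beyond the scatter), is a modest change, and it leaves compound 2 with the lower of the two numbers.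

Compound 3 `CC[C@H](C)[C@H](N)CN(C(=O)[C@@H]1C[C@H]1c1ccccc1)c1ccc(-c2ccc(CN(C)C)cc2)cc1` is not yet measured. It differs from compound 2 by dimethylamino in place of methoxy on a saturated chain carbon bound to an aromatic carbon. Going by the values given here, no measured step touches this position in the same way: the one step available, a 2.1-fold lower number from compound 1 to compound 2 (0.31 log units; beyond the scatter), exchanges one aromatic substituent for another and only shows that this part of the molecule accepts a change of group without a large shift. Compound 3 is therefore expected to stay close to compound 2, with a 1.1-fold higher number from compound 2 to compound 3 (0.06 log units; within the scatter) as the expected step, inside the usual scatter. The estimate for compound 3 in this assay is 40 nM, with a range from 15 nM to 120 nM.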

Compound 3, half-maximal effective concentration: 460 nM
Compound 3: middle estimate off by 12-fold (1.06 log units), on the low side; measured number above the stated range.
By their numbers in this assay, from the lowest: compound 2; then compound 1; then compound 3.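

The position that had taken a change of aromatic substituent with only a modest shift proves sensitive to what sits on the saturated chain carbon bound to an aromatic carbon: in this assay the exchange of methoxy for dimethylamino gives a 13-fold higher number from compound 2 to compound 3 (1.12 log units; beyond the scatter), the largest step among these three compounds. The loss does not depend on methoxymethyl as the point of comparison, since replacing isopropoxy with (dimethylamino)methyl gives a 6.4-fold higher number from compound 1 to compound 3 (0.81 log units; beyond the scatter), and methoxy and dimethylamino are counted alike for hydrogen-bond donors, hydrogen-bond acceptors and net charge, so those counts do not separate them. Nothing available here accounts for the drop.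

The compounds shown leave open whether the loss follows the nitrogen itself or the two methyl groups on it, a question that a (methylamino)methyl or aminomethyl group would help to settle. They also leave open whether the oxygen of the benzylic ether can be carried further, as in a hydroxymethyl group or a longer chain such as ethoxymethyl, without a comparable change in the number.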